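A few compounds are considered here, and "the series" means these few. Any claim that something is new, unique, unknown or untested is made for them only; others in the source may bear on it.

Compound 1, `Nc1sc(Br)c(-c2cccc(C(F)(F)F)c2)c1C(=O)c1ccccc1`, in a functional assay on CHO-K1 cells for agonist activity at adenosine receptor A1 (Homo sapiens), read by GTPgammaS binding; a higher number here means that more compound is needed for the effect, a lower number that less compound is needed: compound 1 gives > 10 uM, which is a limit of the assay and not a number.
Compound 2, `CC(=O)c1cccc(-c2sc(N)c(C(=O)c3ccccc3)c2-c2cccc(C(F)(F)F)c2)c1`: in this assay compound 2 gives > 10 uM, again a limit.
Compound 3, `Nc1sc(-c2ccc([N+](=O)[O-])cc2)c(-c2cccc(C(F)(F)F)c2)c1C(=O)c1ccccc1`: in this assay compound 3 gives > 10 uM, also a limit.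

Compound 3 therefore stands nowhere on a scale of numbers: it sits at the limit, and so do the other two, as the limit of > 10 uM in this assay, at which 3 of the 3 values shown sit, records. The three measured steps between them, a step that the two limits leave unreadable from compound 1 to compound 2, a step that the two limits leave unreadable from compound 1 to compound 3 and a step that the two limits leave unreadable from compound 2 to compound 3, cannot be sized, since both ends of each are limits.

Compound 4, `CCOC(=O)c1c(N)sc(-c2ccc([N+](=O)[O-])cc2)c1-c1cccc(C(F)(F)F)c1`, differs from compound 3 in one place: ethoxy in place of phenyl on a carbonyl carbon. Among the compounds with values here, none of the measured steps touches the carbonyl carbon; all three exchange a group on an aromatic carbon, and all three are unreadable. Within the data shown here, no measured step therefore bears on this change, and no direction can be taken from the data.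

With compound 3 at the limit, the expected step from compound 3 to compound 4 in this assay is guessed rather than derived, at a step that the limit leaves unreadable from compound 3 to compound 4. Compound 4 is estimated at 15 uM, within a range from 3 uM to 60 uM, and most probably the assay will again report only a limit.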

Compound 4, concentration for half-maximal effect: > 10 uM
Compound 4 ended at the assay's limit; the forecaster's own chance of this, stated with the estimate: 80%; the middle value does not contradict the limit.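

In this assay compound 4 gives > 10 uM, which is a limit of the assay and not a number. Compound 3 also sits at a limit, so the exchange of benzoyl for ethoxycarbonyl between compound 3 and compound 4 cannot be sized. The compounds shown leave open how any change to the shared core alters the concentration needed for the effect, since none has a readable value: the limit of > 10 uM in this assay, at which 4 of the 4 values shown sit.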